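This account rests on a few compounds, and the source may have more. Where it says the series, first, only, none or still open, it means among the compounds named here.

Of the compounds shown here, two have been measured so far in an assay on nucleic acid for inhibition of Nucleic Acid, read by fluorescence, tested at 100 uM; on this read-out higher numbers stand for more inhibition at the one concentration tested (going by the name of the read-out) and lower numbers for less inhibition. Compound 1 `CCCCN(CCCC)Cc1cn(CC(O)COC(=O)NCc2ccccc2)nn1` gives 42% in this assay. Compound 2 `O=C(COc1ccccc1)OC1CCCCC1n1cc(CN2CCC(c3ccccc3)CC2)nn1`, built on a different core, gives 42% in this assay. Compound 1 thus stands level with compound 2 at the digits shown, and the two values lie within the usual scatter of this kind of measurement, so no order between them can be read.

Compound 3 `CCCCN(CCCC)Cc1cn(CC(O)COCc2ccccc2)nn1` has not yet been measured. It keeps the core of compound 1 and differs from it in one place: benzyl in place of benzylcarbamoyl on an oxygen on a saturated carbon. Among the compounds with values here, no measured pair of compounds here differs in just this way, and the effect of the change has to be estimated without a template. The expected step is estimated as a number 4 percentage points lower from compound 1 to compound 3 (within the scatter), a shift that may well stay within the scatter, leaning only slightly toward less inhibition. Compound 3 is therefore expected to give about 38% in this assay, with a plausible range from 18% to 58%.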

Compound 3, a percentage reported as inhibition, at one concentration (the size of the read-out at that concentration, not a potency): 6%
Beside the measured number, compound 3's estimate is 32 percentage points above it, outside the stated range (below it).
By their numbers in this assay, from the lowest: compound 3; then compounds 1 and 2 (each within the scatter of the next).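

In this assay, within the data shown here, putting benzyl in place of benzylcarbamoyl on an oxygen on a saturated carbon gives a number 36 percentage points lower from compound 1 to compound 3 (beyond the scatter), the first step here that can be read from a single change, and it shows that the read-out is sensitive to what sits at this position. Both groups carry the same six-membered aromatic ring of carbon only, so keeping that ring is not enough to hold the level of inhibition; what leaves with the change is the part of benzylcarbamoyl that holds the carbonyl, the nitrogen and the one hydrogen-bond donor. Nothing measured here explains the fall, and since these features leave together, the data cannot assign it to any one of them.

The compounds shown leave open which of these features matters, and a benzoyl group, which keeps the carbonyl and the ring but has no nitrogen, would help to separate them. They also leave open whether the ring is needed at all, which a methylcarbamoyl group in the same place would test, and whether the step would be of similar size on another core.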